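The compounds below may be only part of what the source reports. "The series", "measured", "known", "first", "only" and "open" are said of these compounds alone.

In a functional assay for inhibition, with Homo sapiens as the target (a higher number here means that more compound is needed for the effect, a lower number that less compound is needed), compound 1 (`CC(=O)Nc1ccc(C2=NNC(=O)CC2)cc1`) gives 1 ug/mL and compound 2 (`CCCC(=O)Nc1ccc(C2=NNC(=O)CC2)cc1`) gives 1.44 ug/mL. Between them lies a 1.4-fold higher number from compound 1 to compound 2 (0.16 log units; within the scatter). Compound 3 (`O=C1CCC(c2ccc(NC(=O)CCCCl)cc2)=NN1`) reports only a limit in this assay, > 46.4 ug/mL, and not a number. The measured steps that reach it are both large: an at least 46-fold higher number from compound 1 to compound 3 (1.66 log units; beyond the scatter), and an at least 32-fold higher number from compound 2 to compound 3 (1.50 log units; beyond the scatter).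

Compound 4 (`CCCNCC(=O)Nc1ccc(C2=NNC(=O)CC2)cc1`) differs from compound 3 as follows: propylamino in place of 2-chloroethyl on a saturated chain carbon bound to a carbonyl carbon. In words, propylamino stands in place of 2-chloroethyl on a saturated chain carbon bound to a carbonyl carbon. Compound 4 carries no chloro, and chloro is the one difference in an at least 32-fold higher number from compound 2 to compound 3 (1.50 log units; beyond the scatter), so a large step to a lower number is expected in this assay. For the measured compounds named here, no measured compound carries propylamino, so the step back may be only partial. The expected change is an at least 9.2-fold lower number from compound 3 to compound 4 (0.96 log units; beyond the scatter). For compound 4 the estimate is 5 ug/mL, with an expected range of 1 ug/mL to 40 ug/mL.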

Compound 4, half-maximal effective concentration: about 46.4 ug/mL
Compound 4: middle estimate off by 9.3-fold (0.97 log units), on the low side, and the stated range ends below it.
By their numbers in this assay, from the lowest: compounds 1 and 2 (each within the scatter of the next); then compound 4.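

Dropping chloro does not by itself bring the number in this assay back to that of the simple acyl chains, as the change gives a number no higher from compound 3 to compound 4 (the limit leaves the size open) and propylamino on a saturated chain carbon bound to a carbonyl carbon shows a large step in both comparisons: a 32-fold higher number from compound 2 to compound 4 (1.51 log units; beyond the scatter) and a 46-fold higher number from compound 1 to compound 4 (1.67 log units; beyond the scatter). Up to now chloro was the one difference tied to a large rise, whereas compound 4 shows such a rise with no chloro at all, so this position tolerates ethyl but not every larger chain. The step from compound 3 to compound 4 cannot be read, and compound 4 reaches the figure that is only a limit for compound 3: the limit of > 46.4 ug/mL in this assay, at which 1 of the 4 values shown sits.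

From the compounds shown here alone, it remains open whether a longer plain alkyl chain would stay with compound 1 and compound 2. The same holds for an ether or a carboxylic acid at this place.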